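From ethyl to acetyl: expectations for compound 3

The compounds below may be only part of what the source reports. "The series", "measured", "known", "first", "only" and "open" are said of these compounds alone.

Results in a functional assay for inhibition, with Homo sapiens as the target (a higher number here means a weaker inhibitor, a lower number a stronger inhibitor), so far:
- compound 1 `CN1CC/C(=C\c2cc(C(C)(C)C)c(O)c(C(C)(C)C)c2)C1=O` gives 150 nM
- compound 2 `CCN1CC/C(=C\c2cc(C(C)(C)C)c(O)c(C(C)(C)C)c2)C1=O` gives 150 nM

Level with compound 1, compound 2 gives 150 nM. Compound 3 `CC(=O)N1CC/C(=C\c2cc(C(C)(C)C)c(O)c(C(C)(C)C)c2)C1=O`, not yet measured, carries acetyl in place of ethyl on an amide-type nitrogen in a ring. Among the measured compounds shown here, the one measured step that bears on this is no change at the digits printed from compound 1 to compound 2 (within the scatter). That step involved no acetyl, so it is only a weak guide. No step beyond the scatter is therefore expected in this assay, but with wide uncertainty. The expected change is a 1.3-fold higher number from compound 2 to compound 3 (0.12 log units; within the scatter). Compound 3 is estimated at 200 nM, with an expected range of 50 nM to 800 nM.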

Compound 3, half-maximal inhibitory concentration: 350 nM
Compound 3: the middle estimate sits 1.8-fold (0.24 log units) below what was measured; the range from low to high includes it.
By their numbers in this assay, from the lowest: compounds 1 and 2 (each within the scatter of the next); then compound 3.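

In this assay acetyl in place of ethyl gives a 2.3-fold higher number from compound 2 to compound 3 (0.37 log units; beyond the scatter) and acetyl in place of methyl gives a 2.3-fold higher number from compound 1 to compound 3 (0.37 log units; beyond the scatter) so the group on this amide-type nitrogen can matter, which the level pair of compound 1 and compound 2 could not show. The step is modest, and it comes with a group that adds a carbonyl and a hydrogen-bond acceptor. No measured evidence explains it.

Open, going by these compounds, is whether the bare amide hydrogen at this nitrogen would do better or worse. Also open, on these data alone, is how a longer chain such as butyl, or a chain ending in an amine or a carboxylic acid, would compare.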